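This account rests on a few compounds, and the source may have more. Where it says the series, first, only, none or still open, it means among the compounds named here.

Two macrolide lactones from this study have been tested in a functional assay on SK-OV-3 cells (Homo sapiens) for cytotoxicity; a higher number here means that more compound is needed for the effect, a lower number that less compound is needed. Compound 1, `CC/C=C\C/C=C\C[C@H](O)[C@H](O)/C=C/[C@@H]1C/C=C\CCCC(=O)O1`, gives 6.5 ug/mL. Compound 2, `CCCCC/C=C\C[C@H](O)C(/C=C/[C@@H]1C/C=C\CCCC(=O)O1)OC`, gives 13 ug/mL, the higher of the two numbers, with compound 1 the nearest to it and the two values lying within the usual scatter of each other. Within the data shown here, no single-point step between them is recorded, since they differ in more than one place.

Compound 3, `CC/C=C\C/C=C\C[C@H](O)C(/C=C/[C@@H]1C/C=C\CCCC(=O)O1)OC`, has not yet been measured. It differs from compound 2 in one place: but-1-en-1-yl in place of butyl on a saturated chain carbon bound to a double-bonded chain carbon. Compound 1 already carries the same but-1-en-1-yl chain, and its number sits close to that of compound 2, so no step beyond the scatter is expected for this change. Compound 3 is therefore estimated at 9 ug/mL, with a plausible range from 4 ug/mL to 20 ug/mL, a step of a 1.4-fold lower number from compound 2 to compound 3 (0.16 log units; within the scatter) that is expected to stay within the scatter.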

Compound 3, concentration for half-maximal effect: 5.1 ug/mL
Beside the measured number, compound 3's estimate is 1.8-fold (0.25 log units) above it; low and high end bracket the measured number.
By their numbers in this assay, from the lowest: compounds 3, 1 and 2 (each within the scatter of the next, the first and the last beyond it).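

In this assay, putting but-1-en-1-yl in place of butyl on a saturated chain carbon bound to a double-bonded chain carbon gives a 2.5-fold lower number from compound 2 to compound 3 (0.41 log units; beyond the scatter) and so shows a modest response to this single change, which the earlier pair, differing in more than one place, could not isolate. Both chains have the same count of heavy atoms, so the step goes with the added double bond and not with a change in chain size. Nothing available here explains the step.

From the compounds shown here alone, whether a longer chain, a terminal phenyl group or a triple bond in this place would move the number further remains open. Going by these compounds, it is also open whether the same step would appear with an amine or a carboxylic acid at the end of this chain.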